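The source may hold more compounds than are shown below. What is called first, only, known or untested is meant among the compounds shown, and "the series" means these compounds.

Going by these compounds, in a functional assay on HUVEC cells (Homo sapiens) for antiproliferative activity, read by MTT assay, with a stated time of 24 h (a higher number here means a weaker inhibitor, a lower number a stronger inhibitor), compound 2 (`C=CCc1cc(-c2ccc(F)cc2)ccc1O`) gives > 100000 nM, which is a limit of the assay and not a number, so its true position is unknown. Compound 3 (`C=CCc1cc(-c2ccc(OC)cc2)ccc1O`) carries methoxy in place of fluoro on an aromatic carbon, para to a large group: methoxy in place of fluoro on an aromatic carbon. Compound 1 (`C=CC(C)(C)c1cc(-c2ccc(OC)cc2)ccc1O`) also carries methoxy and gives > 100000 nM, again a limit. No measured step sizes this change, so no direction can be argued, and the expected step, a number no higher from compound 2 to compound 3 (the limit leaves the size open), is none beyond the scatter in this assay. Compound 3 is estimated at 100000 nM, with an expected range of 50000 nM to 200000 nM.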

Compound 3, half-maximal inhibitory concentration: > 100000 nM
Compound 3: only a limit was reported; the forecaster's own chance of this, stated with the estimate: 70%; the middle value lies on the limit itself.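

Going by these compounds alone, no step from compound 1 or compound 2 to compound 3 can be read, as all three compounds give only a limit: the limit of > 100000 nM in this assay, at which 3 of the 3 values shown sit. The compounds shown leave open whether either change, methoxy for fluoro or allyl for 1,1-dimethylprop-2-en-1-yl, alters activity at all.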